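A few compounds are considered here, and "the series" means these few. Any claim that something is new, unique, unknown or untested is made for them only; others in the source may bear on it.

Measured compounds:
compound 1 `Nc1cccc(-c2cn(CC(=O)Nc3nc4ccccc4s3)nn2)c1` — 1110 nM
compound 2 `Cc1csc(NC(=O)Cn2cc(-c3ccccc3Cl)nn2)n1` — 1240 nM
compound 3 `O=C(Cn1cc(-c2ccccc2Cl)nn1)Nc1nc2ccccc2s1` — > 30000 nM

In a functional assay on BMDM cells (Mus musculus, strain C57BL/6) for inhibition, with a stated time of 2 days (a higher number here means a weaker inhibitor, a lower number a stronger inhibitor), compound 1 gives 1110 nM and compound 2 gives 1240 nM; these two sit within the scatter of each other. Compound 3 reaches only a limit of the assay, > 30000 nM. The step of an at least 27-fold lower number from compound 3 to compound 1 (1.43 log units; beyond the scatter) follows the change (3-aminophenyl in place of 2-chlorophenyl on an aromatic carbon); since compound 3 sits at the limit of > 30000 nM in this assay, at which 1 of the 3 values shown sits, the true size of that step is not known. How the core of compound 2 differs from that of compound 3 is not broken down here. Compound 4 `Cc1csc(NC(=O)Cn2cc(-c3cccc(N)c3)nn2)n1` carries the same change on the core of compound 2: 3-aminophenyl in place of 2-chlorophenyl on an aromatic carbon. A step of a 2.1-fold lower number from compound 2 to compound 4 (0.32 log units; beyond the scatter) is expected, smaller than the earlier one, because compound 2 already gives 1240 nM rather than a limit. Compound 4 is estimated at 600 nM, expected between 150 nM and 2500 nM.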

Compound 4, half-maximal inhibitory concentration: 250 nM
The estimate for compound 4 lay 2.4-fold (0.38 log units) above the measured number; the measured number falls inside the stated range.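

In this assay, the change from 2-chlorophenyl to 3-aminophenyl also lowers the number on the core of compound 2, giving a 5.0-fold lower number from compound 2 to compound 4 (0.70 log units; beyond the scatter). The direction of the step therefore holds on both cores shown, but its size does not carry over from one core to the other: the same change on two cores in this assay, an at least 27-fold lower number (1.43 log units; beyond the scatter) from compound 3 to compound 1 and a 5.0-fold lower number (0.70 log units; beyond the scatter) from compound 2 to compound 4, at least 5.4-fold (0.73 log units) apart, beyond the scatter of two such steps. Going by these compounds, how far apart the two steps truly lie remains unknown, since compound 3 gives only a limit of the assay: the limit of > 30000 nM in this assay, at which 1 of the 4 values shown sits.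

The change removes 2-chlorophenyl and brings in 3-aminophenyl in a single swap, and the compounds shown leave open what each part contributes. A plain phenyl group on either core would bear on that question.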